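The source may report more compounds than this note shows. Statements on the series, on what has been measured and on what is new or still open speak of the compounds shown alone.

Compound 1, `C[C@H](NC(=O)CN(c1nc(Cl)nc2[nH]cnc12)C1CC1)C(=O)OCc1ccccc1`, gives 41.2% in a functional assay on the whole organism (Tail, strain ICR) with Mus musculus as the target, in the tail flick test, with a stated time of 30 min, at a dose of 25 umol/kg by the oral route; a lower number here means a weaker effect, a higher number a stronger effect of the compound at the dose given. Among the compounds with values here, compound 2, `NCCCC[C@H](NC(=O)CN(c1nc(Cl)nc2[nH]cnc12)C1CC1)C(=O)OCc1ccccc1`, gives 26.1% and stands lowest of the two numbers known here; the step of a number 15.1 percentage points lower from compound 1 to compound 2 (beyond the scatter) separates them. Compound 3, `CSCC[C@H](NC(=O)CN(c1nc(Cl)nc2[nH]cnc12)C1CC1)C(=O)OCc1ccccc1`, differs from compound 2 by methylsulfanyl in place of 2-aminoethyl on a saturated chain carbon, three bonds along the chain from an amide-type nitrogen and a carbonyl carbon. Within the data shown here, only that one step bears on the change, and it is a related but not identical difference, so the expectation for compound 3 is loose: its number is expected to move back toward compound 1, by roughly a number 9.9 percentage points higher from compound 2 to compound 3 (within the scatter). Compound 3 is therefore estimated at 36%, within 20% to 52%.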

Compound 3, a percentage reported as activity, at one dose (the size of the read-out at that dose, not a potency): 22.2%
For compound 3 the middle estimate is 13.8 percentage points above the measured one; low and high end bracket the measured number.
By their numbers in this assay, from the lowest: compounds 3 and 2 (each within the scatter of the next); then compound 1.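

In this assay the change to methylsulfanyl from 2-aminoethyl gives a number 3.9 percentage points lower from compound 2 to compound 3 (within the scatter) and so does not separate these two chains at this position. Adding (methylsulfanyl)methyl on this chain carbon gives a number 19 percentage points lower from compound 1 to compound 3 (beyond the scatter) and thus, like 3-aminopropyl, a number beyond the scatter below that of compound 1. Nothing available explains this result. Still open, going by these compounds, is how a carboxylic acid or a hydroxyl group at the end of the chain would read in this position, and whether a longer unbranched hydrocarbon chain would match these two.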